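A few compounds are considered here, and "the series" means these few. Any claim that something is new, unique, unknown or untested is made for them only; others in the source may bear on it.

Of the compounds shown here, three have been measured in an assay on isolated protein for inhibition of polyamine deacetylase HDAC10 (Homo sapiens) (on this read-out higher numbers stand for weaker inhibition and lower numbers for stronger inhibition), and a fourth awaits measurement. Compound 2 `COc1ccc(C(=O)c2ccc3c(ccn3Cc3ccc(C(=O)NO)cc3)c2)cc1` gives 59800 nM in this assay. Compound 1 `COc1ccc(C(=O)c2ccc3c(ccn3Cc3ccc(C(=O)NO)cc3)c2)cc1OC` carries one change relative to compound 2, (methoxy in place of hydrogen on an aromatic carbon). In this assay compound 1 gives 18900 nM, a step of a 3.2-fold lower number from compound 2 to compound 1 (0.50 log units; beyond the scatter). Compound 3 `COc1ccc(C(=O)c2ccc3c(ccn3S(=O)(=O)c3cccc(/C=C/C(=O)NO)c3)c2)cc1` has a different core; the difference between the two cores is not broken down here. Compound 3 gives 5890 nM, the lowest of the three numbers.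

Compound 4 `COc1ccc(C(=O)c2ccc3c(ccn3S(=O)(=O)c3cccc(/C=C/C(=O)NO)c3)c2)cc1OC` is obtained from compound 3 by the same change that takes compound 2 to compound 1, (methoxy in place of hydrogen on an aromatic carbon), at a place described in the same words in both pairs. The change is seen only once among the measured compounds, so the expectation rests on that single step. If it repeats on the core of compound 3, the expected step is a 2.9-fold lower number from compound 3 to compound 4 (0.47 log units; beyond the scatter), beside the measured 3.2-fold lower number from compound 2 to compound 1 (0.50 log units; beyond the scatter). Compound 4 is therefore estimated at 2000 nM in this assay, with a range from 900 nM to 4500 nM.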

Compound 4, half-maximal inhibitory concentration: 8240 nM
Compound 4: the middle estimate sits 4.1-fold (0.61 log units) below what was measured; measured number outside the range, above it.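

In this assay, the gain seen on the core of compound 2 did not carry over to the core of compound 3: going from 4-methoxyphenyl to 3,4-dimethoxyphenyl there gives a 1.4-fold higher number from compound 3 to compound 4 (0.15 log units; within the scatter), so no real change is seen on this core. The two steps disagree: the same change on two cores in this assay, a 3.2-fold lower number (0.50 log units; beyond the scatter) from compound 2 to compound 1 and a 1.4-fold higher number (0.15 log units; within the scatter) from compound 3 to compound 4, 4.4-fold (0.65 log units) apart, beyond the scatter of two such steps. Among these compounds, this shows that, in this series, the effect of this methoxy on one core cannot be assumed on the other, but with only one pair on each core it does not show which feature of the cores is responsible, or how the change would behave on any further core.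

The compounds shown leave open whether a different group at the same place, such as a hydroxyl, an amine or a longer alkoxy chain, would follow either step. They also leave open how a phenyl carrying no methoxy at all would read on either core.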